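A few compounds are considered here, and "the series" means these few. Any claim that something is new, unique, unknown or untested is made for them only; others in the source may bear on it.

Compound 1 `CCOC(=O)c1ccc(NC(=O)CSc2snnc2-c2ccccc2)c(Br)c1`: >= 232000 nM
Compound 2 `CCOC(=O)c1ccc(NC(=O)CSc2snnc2-c2ccc(Cl)cc2Cl)c(Br)c1`: > 228000 nM
Compound 3 `O=C(CSc1snnc1-c1ccc(Cl)cc1Cl)Nc1ccccc1[N+](=O)[O-]`: > 283000 nM

Of the compounds shown here, three have been tested in an ADME assay on MT4 cells (Homo sapiens) for cytotoxicity; on this read-out higher numbers stand for lower toxicity in this test and lower numbers for higher toxicity in this test. Compound 1 gives >= 232000 nM, which is a limit of the test rather than a number. Compound 2 gives > 228000 nM, also a limit. Compound 3 gives > 283000 nM, again a limit. Compound 2 and compound 1 differ in one place, (phenyl in place of 2,4-dichlorophenyl on an aromatic carbon), and the step that the two limits leave unreadable from compound 2 to compound 1 cannot be sized. The difference between the core of compound 3 and the core of compound 2 is not broken down here. Compound 4 `O=C(CSc1snnc1-c1ccccc1)Nc1ccccc1[N+](=O)[O-]` is not yet measured; it carries the same change as compound 1 does relative to compound 2, namely (phenyl in place of 2,4-dichlorophenyl on an aromatic carbon). Because (the limit of > 228000 nM in this assay, at which 1 of the 3 values shown sits), the limit of > 283000 nM in this assay, at which 1 of the 3 values shown sits, and the limit of >= 232000 nM in this assay, at which 1 of the 3 values shown sits, all sit at a limit, compound 4 is expected to give 280000 nM. The expected step is a number no higher from compound 3 to compound 4 (the limit leaves the size open).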

Compound 4, half-maximal cytotoxic concentration: >= 246000 nM
Compound 4: only a limit was reported (the forecaster's own chance of this, stated with the estimate: 85%); the middle value lies beyond the limit too.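

Compound 3 and compound 4 are each reported only as a limit of the test, and no step can be read between them. The compounds shown leave open whether phenyl in place of 2,4-dichlorophenyl changes the read-out at all in this assay.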